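Mirror-Image Change in a Cyanoguanidine Pair

The compounds below may be only part of what the source reports. "The series", "measured", "known", "first", "only" and "open" are said of these compounds alone.

Measured so far:
Compound 1, `N#CN/C(=N\C1CCCC1)Nc1cc(C(F)(F)F)cc(C(F)(F)F)c1`, in a functional assay (aorta) with Rattus norvegicus as the target (a higher number here means a weaker inhibitor, a lower number a stronger inhibitor), gives > 300000 nM, which is a limit of the assay rather than a number.
Compound 2, `C[C@H](/N=C(\NC#N)Nc1cc(Cl)cc(Cl)c1)c1ccccc1`, in this assay gives 30000 nM.

Going by the values given here, compound 2 therefore holds the only actual number measured here; the other result, that of compound 1, is the limit (the limit of > 300000 nM in this assay, at which 1 of the 2 values shown sits). The next compound, compound 3, `C[C@@H](/N=C(\NC#N)Nc1cc(Cl)cc(Cl)c1)c1ccccc1`, differs from compound 2 only in the drawing of one centre: the two compounds have the same atoms and bonds and differ only in configuration as drawn: 1 of 2 stereo elements differ; a stereocentre at a saturated chain carbon is drawn S in compound 2 and R in compound 3. Among the compounds with values here, with the same atoms and bonds, no step between measured compounds gives a hint of how large a change to expect in this assay, nor in which direction. For compound 3 the estimate is 40000 nM, between 8000 nM and 200000 nM, with an expected step of a 1.3-fold higher number from compound 2 to compound 3 (0.12 log units; within the scatter) that may well sit within the usual scatter.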

Compound 3, half-maximal inhibitory concentration: 43800 nM
For compound 3 the middle estimate is 1.1-fold (0.04 log units) below the measured one, within the range that was stated.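

Turning the stereocentre at the saturated chain carbon from S to R gives a 1.5-fold higher number from compound 2 to compound 3 (0.16 log units; within the scatter) in this assay. The two configurations therefore cannot be told apart in this read-out, which is something neither compound could show alone. The comparison isolates this one centre, because no other feature of the pair changes: the fact that compounds 2 and 3 differ only in the configuration as drawn

As far as these compounds go, what stays open is whether the two configurations would still read alike if a longer chain, such as an ethyl group, stood on this carbon. Compound 1 differs from compound 2 and compound 3 in more than one place, so it offers no direct comparison that could settle this question.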